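Swapping 3-fluorophenyl for 1,3,4-thiadiazol-2-yl on the sulfonamide nitrogen

A few compounds are considered here, and "the series" means these few. Any claim that something is new, unique, unknown or untested is made for them only; others in the source may bear on it.

In a functional assay on RAW264.7 cells (Mus musculus) for inhibition (a higher number here means a weaker inhibitor, a lower number a stronger inhibitor), compound 1 (`CCOC(=O)C1=CCCCC1S(=O)(=O)Nc1cccc(F)c1`) gives 150 nM and, together with compound 2 (`CCOC(=O)C1=CCCCC1S(=O)(=O)Nc1cccc(F)c1F`) at 140 nM in the same run of numbers, marks the upper end of the three values in hand. Compound 3 (`CCOC(=O)C1=CCCCC1S(=O)(=O)Nc1ccc(C)cc1Cl`) gives 41 nM and so shows a lower number than compound 1 does.

The step to compound 4 (`CCOC(=O)C1=CCCCC1S(=O)(=O)Nc1nncs1`) is 1,3,4-thiadiazol-2-yl in place of 3-fluorophenyl on a sulfonamide nitrogen with the shared core unchanged: 1,3,4-thiadiazol-2-yl in place of 3-fluorophenyl on a sulfonamide nitrogen. Among the measured compounds shown here, only one measured step changes a single place, a 1.1-fold lower number from compound 1 to compound 2 (0.03 log units; within the scatter) for fluoro in place of hydrogen on an aromatic carbon, and it lies within the scatter. That step leaves the ring itself in place. For the measured compounds named here, every measured compound keeps a six-membered aromatic ring of carbon only on that nitrogen, so the data hold no direct precedent for this exchange, and neither size nor direction can be read from them. The whole group changes here, so a step beyond the scatter toward a higher number is expected, on judgement rather than measurement. The estimate amounts to a 6.0-fold higher number from compound 1 to compound 4 (0.78 log units; beyond the scatter) as the expected step. In this assay the estimated value for compound 4 is 900 nM with an expected range of 200 nM to 5000 nM at this stage.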

Compound 4, half-maximal inhibitory concentration: > 10000 nM
Compound 4 gave a limit, no number (the forecaster's own chance of this, stated with the estimate: 15%); middle value at least 11-fold (1.04 log units) from the limit.
By their numbers in this assay, from the lowest: compound 3; then compounds 2 and 1 (each within the scatter of the next). At a limit, above all of these: compound 4.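

In this assay, among the compounds shown here, the exchange of the whole group on the sulfonamide nitrogen gives an at least 66-fold higher number from compound 1 to compound 4 (1.82 log units; beyond the scatter), whereas the only earlier single-place step, a 1.1-fold lower number from compound 1 to compound 2 (0.03 log units; within the scatter), left the aromatic ring in place and stayed within the scatter. The group on this nitrogen therefore shows a sensitivity that the fluoro change on the ring did not reveal, and 1,3,4-thiadiazol-2-yl does not serve as a replacement for 3-fluorophenyl in this assay. Compound 4 gives a limit of the assay and not a number, so the step has a lower bound but no full size: the limit of > 10000 nM in this assay, at which 1 of the 4 values shown sits.

Still open, on these data alone, is whether the loss follows the change of ring size or the hetero atoms of the new ring; a thienyl or pyridyl group on the sulfonamide nitrogen would separate these two readings. For the compounds shown here, also open is how the series responds at the ethyl ester of the shared core, where a carboxylic acid or an amide would give a first reading of that part of the molecule.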